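From thiophen-2-yl to thiophen-3-yl in compound 3

The compounds below may be only part of what the source reports. "The series", "measured", "known", "first", "only" and "open" are said of these compounds alone.

Of the compounds shown here, three have been measured in a functional assay on Jurkat cells (Homo sapiens) for inhibition; a lower number here means a stronger inhibitor, a higher number a weaker inhibitor. Compound 2 `CCOC(=O)c1cnc(N(C)N2C(=O)C=C(C)C2=O)nc1CC` gives 35 nM, and compound 1 `CCOC(=O)c1cnc(NN2C(=O)C=C(C)C2=O)nc1-c1ccsc1` gives 200 nM. Compound 3 `CCOC(=O)c1cnc(N(C)N2C(=O)C=C(C)C2=O)nc1-c1cccs1` gives 94 nM, the second highest of the three numbers.

Compound 4 `CCOC(=O)c1cnc(N(C)N2C(=O)C=C(C)C2=O)nc1-c1ccsc1` has the same atoms as compound 3, joined differently, with thiophen-3-yl in place of thiophen-2-yl on an aromatic carbon. This carbon lies next to the ring nitrogen and ortho to an ethoxycarbonyl group.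

Among the measured compounds shown here, only one measured step changes the group at this place: a 2.7-fold higher number from compound 2 to compound 3 (0.43 log units; beyond the scatter), with thiophen-2-yl in place of ethyl. That step is modest. For the measured compounds named here, compound 1 also carries thiophen-3-yl, but it differs from compound 4 elsewhere, and no measured step compares the two thiophene forms directly. Exchanging one thiophene form for the other is expected to move the number less than the modest step to compound 3 did.

The expected step is a 1.1-fold higher number from compound 3 to compound 4 (0.03 log units; within the scatter), with no change expected beyond the scatter. For compound 4 the estimated value is 100 nM, with an expected range of 45 nM to 220 nM.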

Compound 4, half-maximal inhibitory concentration: 120 nM
Compound 4: middle estimate off by 1.2-fold (0.08 log units), on the low side; the measured number falls inside the stated range.
By their numbers in this assay, from the lowest: compound 2; then compounds 3, 4 and 1 (each within the scatter of the next, the first and the last beyond it).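

In this assay, the direct comparison of the two thiophene forms at this place, next to the ring nitrogen, gives a 1.3-fold higher number from compound 3 to compound 4 (0.11 log units; within the scatter), so moving the ring attachment from thiophen-2-yl to thiophen-3-yl makes no difference that stands out from the scatter. Ethyl now stands apart from both thiophene forms, since replacing it with thiophen-3-yl gives a 3.4-fold higher number from compound 2 to compound 4 (0.54 log units; beyond the scatter), in line with the earlier step to thiophen-2-yl. Among the compounds shown here, the single change on the nitrogen can also be read for the first time: adding the methyl gives a 1.7-fold lower number from compound 1 to compound 4 (0.22 log units; within the scatter), which also lies within the scatter.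

No measurement shown here offers an explanation for these numbers. The compounds shown leave open whether propyl, cyclopropyl or phenyl at this place would give a number nearer that of the ethyl compound, and how a larger group such as ethyl on the nitrogen would compare with methyl.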